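Amide-side exchange and expected permeability of compound 3

The source may report more compounds than this note shows. Statements on the series, on what has been measured and on what is new or still open speak of the compounds shown alone.

Of the compounds shown here, two have been measured so far. Compound 1 `O=C(Nc1ccc(Cl)cc1)c1cc([N+](=O)[O-])ccc1Cl` gives 536 10^-6 cm/s in an ADME assay for permeability, using PAMPA; a lower number here means that the compound crosses the layer more slowly, a higher number that the compound crosses the layer faster. Compound 2 `CN(C)CCC(=O)Nc1cccc(-c2nc3ccccc3s2)c1` gives 2080 10^-6 cm/s in this assay, the higher of the two numbers, and the gap to compound 1 lies beyond the usual scatter of repeated measurements. Going by the values given here, with only two compounds measured and no pair differing in a single place, no measured step is available to calibrate the series.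

Compound 3 `O=C(Nc1cccc(-c2nc3ccccc3s2)c1)c1cccnc1Cl` is the next compound for this assay. Its structure differs from compound 2 in one place: 2-chloropyridin-3-yl in place of 2-(dimethylamino)ethyl on a carbonyl carbon. The group that leaves has no ring; the group that enters carries one six-membered aromatic ring with one hetero atom, and the amide-type nitrogen on the other side of the carbonyl carbon is unchanged.

For compound 3 the step of a 1.7-fold lower number from compound 2 to compound 3 (0.24 log units; within the scatter) is expected to run downward and to be modest, quite possibly no larger than the scatter. The estimate for compound 3 in this assay is 1200 10^-6 cm/s, with a range from 450 10^-6 cm/s to 2600 10^-6 cm/s.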

Compound 3, apparent permeability: 677 10^-6 cm/s
Estimate against measurement, compound 3: 1.8-fold (0.25 log units) above, and the stated range covers the measured number.
By their numbers in this assay, from the lowest: compounds 1 and 3 (each within the scatter of the next); then compound 2.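

In this assay, going by these compounds alone, the exchange of 2-(dimethylamino)ethyl for 2-chloropyridin-3-yl on a carbonyl carbon gives a 3.1-fold lower number from compound 2 to compound 3 (0.49 log units; beyond the scatter) and is the first step that changes a single place. With the amide-type nitrogen and the rest of the core held constant, this one position is enough to move the number beyond the scatter, and within this pair the group without a ring carries the higher number. No measurement in hand bears on the origin of this step, so it stands as an observation only.

The single step changes several things at once: the open chain and its amine nitrogen leave, while an aromatic ring, its ring nitrogen and a chlorine enter, and the compounds shown do not separate these contributions. From the compounds shown here alone, a plain phenyl or an unsubstituted pyridin-3-yl on the same carbonyl carbon, or a longer chain ending in a dimethylamino group, would divide the step into smaller parts, and whether the same exchange gives a similar step on another core also remains open.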